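A few compounds are considered here, and "the series" means these few. Any claim that something is new, unique, unknown or untested is made for them only; others in the source may bear on it.

Working notes on the series.

Compound 1, `O=C(O)c1cccc(CCCCCCC(=O)c2ncc(-c3ccccn3)o2)c1`, is the reference point of this comparison. In an assay for inhibition of Fatty-acid amide hydrolase 1 (Rattus norvegicus) (a higher number here means a weaker inhibitor, a lower number a stronger inhibitor), compound 1 gives only a limit, > 600 nM, not a number. That places compound 1 at the limit of > 600 nM in this assay, at which 1 of the 3 values shown sits, so compound 1 stands as the weakest point shown in this assay, with no number to anchor it. Compound 2, `O=C(CCCCCCc1cccnc1)c1ncc(-c2ccccn2)o1`, gives 32 nM in this assay. Compound 3, `COc1ccc(CCCCCCC(=O)c2ncc(-c3ccccn3)o2)cc1`, gives 6.2 nM in this assay.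

The step under consideration is to compound 4, `O=C(CCCCCCc1cccc(C(F)(F)F)c1)c1ncc(-c2ccccn2)o1`. The change is trifluoromethyl in place of carboxy on an aromatic carbon, with the group meta to a large group on a six-membered aromatic ring of carbon only.

Two measured steps start from the same compound 1 and swap away the 3-carboxyphenyl end group: an at least 18-fold lower number from compound 1 to compound 2 (1.27 log units; beyond the scatter) and an at least 96-fold lower number from compound 1 to compound 3 (1.98 log units; beyond the scatter). Both are large and in the same direction, and the gap between them, a 5.2-fold lower number from compound 2 to compound 3 (0.71 log units; beyond the scatter), is modest. Removing the carboxy group has therefore been followed by a large lowering of the number in every case shown, and a step of similar size is expected for the trifluoromethyl replacement.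

The expected step is an at least 40-fold lower number from compound 1 to compound 4 (1.60 log units; beyond the scatter). Compound 4 is estimated at 15 nM in this assay, within 4 nM to 60 nM.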

Compound 4, inhibition constant: 1 nM
Compound 4: the middle estimate sits 15-fold (1.18 log units) above what was measured; measured number below the stated range.
By their numbers in this assay, from the lowest: compound 4; then compound 3; then compound 2. At a limit, above all of these: compound 1.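

In this assay, exchanging only the group on the aromatic ring, with the chain, the ring and the shared core left as they are, gives an at least 600-fold lower number from compound 1 to compound 4 (2.77 log units; beyond the scatter). Compounds 2 and 3 each replace the whole 3-carboxyphenyl end group, whereas this step shows that the change of carboxy alone is enough for a large lowering of the number, and with it compound 3 gives 6.2 nM while compound 4 gives 1 nM. The true size of this step stays unknown because compound 1 gives only a limit and not a number: the limit of > 600 nM in this assay, at which 1 of the 4 values shown sits.

The compounds shown leave open whether trifluoromethyl itself contributes to the low number of compound 4 or whether the absence of the carboxylic acid accounts for it, a question that an unsubstituted phenyl end group, or a methyl group, a chlorine atom or a nitrile in the same place, would address. They also leave open how the trifluoromethyl result carries over to a shorter or longer chain, and how an amide or methyl ester of the carboxylic acid would compare with compound 1.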